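Chloro to amino on the fused ring: compound 3 expected

The source may hold more compounds than are shown below. What is called first, only, known or untested is meant among the compounds shown, and "the series" means these compounds.

compound 1 `Nc1nn(C(=O)Nc2ccc(Cc3ccccc3)cc2)c2ccccc12` — 13400 nM
compound 2 `Nc1nn(C(=O)Nc2ccc(Cc3ccccc3)cc2)c2ccc(Cl)cc12` — 588 nM

In a functional assay on COLO 205 cells (Homo sapiens) for antiproliferative activity, read by sulforhodamine B assay, with a stated time of 48 h (on this read-out lower numbers stand for stronger inhibition of growth and higher numbers for weaker inhibition of growth), compound 1 gives 13400 nM and compound 2 gives 588 nM. Compound 2 stands lowest of the two numbers; the step of a 23-fold lower number from compound 1 to compound 2 (1.36 log units; beyond the scatter) is large and beyond the scatter, so compound 2 is the stronger of the two.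

Compound 3 `Nc1ccc2c(c1)c(N)nn2C(=O)Nc1ccc(Cc2ccccc2)cc1` has not yet been measured. It differs from compound 2 by amino in place of chloro on an aromatic carbon, on the six-membered aromatic ring of carbon only that is part of a fused system of two rings. For the measured compounds named here, the only measured step that bears on this position is a 23-fold lower number from compound 1 to compound 2 (1.36 log units; beyond the scatter), which shows that chloro at this carbon, set against hydrogen, brings the number down strongly. Going by the values given here, no measured compound carries an amino at this carbon, so whether amino holds that gain or falls back toward compound 1 is unknown. For compound 3 the expected step is a 5.1-fold higher number from compound 2 to compound 3 (0.71 log units; beyond the scatter) in this assay, a rise in the number but not a full return to compound 1. Compound 3 is therefore estimated at 3000 nM, with a range from 500 nM to 15000 nM.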

Compound 3, concentration for 50% growth inhibition: 13100 nM
Compound 3: middle estimate off by 4.4-fold (0.64 log units), on the low side; low and high end bracket the measured number.
By their numbers in this assay, from the lowest: compound 2; then compounds 3 and 1 (each within the scatter of the next).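

In this assay amino in place of chloro gives a 22-fold higher number from compound 2 to compound 3 (1.35 log units; beyond the scatter) and so removes the gain seen in a 23-fold lower number from compound 1 to compound 2 (1.36 log units; beyond the scatter) on this aromatic carbon of the fused system. Amino in place of hydrogen gives a 1.0-fold lower number from compound 1 to compound 3 (0.01 log units; within the scatter) and leaves compound 3 and compound 1 indistinguishable on this read-out, so amino offers no measurable gain over hydrogen here. Filling this carbon is therefore not enough in itself: chloro and amino are each a single heavy atom at the same place, yet among compound 1, compound 2 and compound 3 only the chloro compound, compound 2, stands apart from the others.

As far as these compounds go, whether the gain extends to other groups at this carbon stays open, for example fluoro, bromo, methoxy or a carboxylic acid, as does whether chloro would give the same step at another carbon of the ring. The data on hand give no measured explanation for the difference between chloro and amino.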